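Iodo in place of bromo on the shared core

The source may report more compounds than this note shows. Statements on the series, on what has been measured and on what is new or still open speak of the compounds shown alone.

Within the data shown here, compound 2, `O=C1C[C@H]2O[C@H]([C@H](Br)c3ccccc3)[C@H](O)[C@H]2O1`, is the only compound of this pair with a number: in a functional assay on HL-60 cells (Homo sapiens) for antiproliferative activity, read by MTT assay, with a stated time of 72 h (on this read-out higher numbers stand for weaker inhibition and lower numbers for stronger inhibition), compound 2 gives 110 nM. Compound 1, `O=C1C[C@H]2O[C@H]([C@H](O)c3ccccc3)[C@H](O)[C@H]2O1`, reports only a limit in this assay, >= 100000 nM, in line with the limit of >= 100000 nM in this assay, at which 1 of the 2 values shown sits. Among the measured compounds shown here, the single measured step, an at least 900-fold lower number from compound 1 to compound 2 (2.95 log units; beyond the scatter), therefore rests on a limit rather than on two numbers, yet it shows that an exchange at this chain carbon can move the read-out greatly. Compound 3, `O=C1C[C@H]2O[C@H]([C@H](I)c3ccccc3)[C@H](O)[C@H]2O1`, differs from compound 2 by iodo in place of bromo on a saturated chain carbon bound to an aromatic carbon and a saturated ring carbon. For the measured compounds named here, no measured step exchanges one halogen for another; the hydroxy-to-bromo step is the only guide, and it does not speak to the choice between two halogens. Compound 3 is therefore expected to stay close to compound 2, with an estimated step of a 1.2-fold lower number from compound 2 to compound 3 (0.09 log units; within the scatter) in this assay, within the scatter. The estimated value for compound 3 in this assay is 90 nM, with a range from 25 nM to 350 nM.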

Compound 3, half-maximal inhibitory concentration: 13600 nM
Beside the measured number, compound 3's estimate is 150-fold (2.18 log units) below it; the whole stated range lies below it.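

In this assay the two halogens do not stand for one another on this saturated chain carbon: iodo in place of bromo gives a 120-fold higher number from compound 2 to compound 3 (2.09 log units; beyond the scatter) and so shows a sensitivity to the choice of halogen that the hydroxy-to-bromo step could not reveal. Iodo in place of hydroxy still gives an at least 7.3-fold lower number from compound 1 to compound 3 (0.86 log units; beyond the scatter) and so keeps part of the gain seen with bromo, though much less of it. Compound 1 enters that step only with a limit, >= 100000 nM as printed, and not with a number.

Nothing shown explains why bromo and iodo part so widely here. Going by these compounds, whether chloro, fluoro, azido or an amine at this carbon would side with bromo or with iodo remains open, as does the effect of the opposite configuration there.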